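The compounds below may be only part of what the source reports. "The series", "measured", "known", "first", "only" and "open" are said of these compounds alone.

Working notes on the series. Compound 2 `CCC1Nc2ccccc2C(=O)N1Cc1ccc(-c2ccccc2-c2nn[nH]n2)cc1` is the reference point for the step considered here. In a functional assay on the whole organism for inhibition, with Rattus norvegicus as the target, at a dose of 15 mg/kg by the intravenous route (on this read-out higher numbers stand for more inhibition at the one dose given (going by the name of the read-out) and lower numbers for less inhibition), compound 2 gives 88%. Compound 1 `CCCCC1Nc2ccccc2C(=O)N1Cc1ccc(-c2ccccc2-c2nn[nH]n2)cc1` carries butyl where compound 2 carries ethyl; in this assay compound 1 gives 88%. Compound 3 `CCC1Nc2ccc(C(C)C)cc2C(=O)N1Cc1ccc(-c2ccccc2-c2nn[nH]n2)cc1` carries isopropyl on an aromatic carbon of the shared core; in this assay compound 3 gives 88%. Compound 2 thus sits within the scatter of both neighbours: no change at the digits printed from compound 1 to compound 2 (within the scatter), and no change at the digits printed from compound 2 to compound 3 (within the scatter).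

Compound 4 `CCCC1Nc2ccccc2C(=O)N1Cc1ccc(-c2ccccc2-c2nn[nH]n2)cc1` differs from compound 2 by methyl in place of hydrogen on a saturated chain carbon, two bonds along the chain from a saturated ring carbon. Read one bond further out, the same difference is ethyl to propyl, so compound 4 lies on the chain between compound 2 and compound 1.

Within the data shown here, the step that bears on this is the one from compound 1 to compound 2, where shortening the same chain by two carbons left the read-out unchanged within the scatter, no change at the digits printed from compound 1 to compound 2 (within the scatter); the step from compound 2 to compound 3 touches another position and also shows no change. No step beyond the scatter is therefore expected in this assay for compound 4, whose expected step is no change at the digits printed from compound 2 to compound 4 (within the scatter). Compound 4 is estimated to give 88% in this assay, with a range from 80% to 95%.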

Compound 4, a percentage reported as inhibition, in the whole organism at one dose (the size of the read-out at that dose, not a potency): 88%
For compound 4 middle estimate and measured number coincide at the digits printed, and the stated range covers the measured number.
By their numbers in this assay, from the lowest: compounds 1, 2, 3 and 4 (each within the scatter of the next).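

In this assay, the propyl chain of compound 4 fills the one length missing at this position, and both of its steps read flat (no change at the digits printed from compound 2 to compound 4 (within the scatter)) and (no change at the digits printed from compound 1 to compound 4 (within the scatter)). Ethyl, propyl and butyl at this position are thus not told apart by this read-out, which the ethyl and butyl ends alone could not show, since an intermediate length might have stood apart from both. No evidence is at hand that bears on this flat result.

Going by these compounds, whether a chain longer than butyl, such as hexyl, or an amine or a carboxylic acid at the end of the chain would move the read-out stays open. The read-out rests on one dose, and any difference in potency among these chain lengths also stays open.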